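Shortening the Linker to an Unsaturated Hydroxamate

The source may hold more compounds than are shown below. What is called first, only, known or untested is meant among the compounds shown, and "the series" means these compounds.

Measured compounds:
compound 1: `O=C(CCCSc1nc(O)cc(CCc2ccccc2)n1)NO`, 205 nM
compound 2: `O=C(CCCCSc1nc(O)cc(CCc2ccccc2)n1)NO`, 40 nM

In an assay on isolated protein for inhibition of histone deacetylase HD2 (Zea mays) (on this read-out higher numbers stand for weaker inhibition and lower numbers for stronger inhibition), compound 1 gives 205 nM. In this assay compound 2 gives 40 nM, the lowest number of the two. Among the compounds with values here, the single step between them, a 5.1-fold lower number from compound 1 to compound 2 (0.71 log units; beyond the scatter), lengthened the saturated chain between the sulfur and the hydroxamic acid by one carbon and brought a clearly lower number.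

Compound 3, `O=C(/C=C/Sc1nc(O)cc(CCc2ccccc2)n1)NO`, goes the other way: 2-(hydroxycarbamoyl)ethenyl in place of 4-(hydroxycarbamoyl)butyl on a sulfur. The chain is now shorter than in either measured compound and carries a double bond. Within the data shown here, only the step from compound 1 to compound 2 bears on this change, and it points to longer chains giving lower numbers. Read in reverse, a shorter chain would be expected to give a higher number, and compound 3 sits further along that direction than compound 1 did, although the double bond has no measured counterpart here. Compound 3 is therefore expected to show a 15-fold higher number from compound 2 to compound 3 (1.18 log units; beyond the scatter) in this assay. Compound 3 is estimated at 600 nM, with a likely range from 150 nM to 2500 nM.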

Compound 3, half-maximal inhibitory concentration: 41000 nM
Beside the measured number, compound 3's estimate is 68-fold (1.83 log units) below it; measured number outside the range, above it.
By their numbers in this assay, from the lowest: compound 2; then compound 1; then compound 3.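

In this assay, putting 2-(hydroxycarbamoyl)ethenyl in place of 4-(hydroxycarbamoyl)butyl on the sulfur gives a 1000-fold higher number from compound 2 to compound 3 (3.01 log units; beyond the scatter), and putting the same group in place of 3-(hydroxycarbamoyl)propyl gives a 200-fold higher number from compound 1 to compound 3 (2.30 log units; beyond the scatter). Both are much larger than the earlier 5.1-fold lower number from compound 1 to compound 2 (0.71 log units; beyond the scatter), so the group on this sulfur can change inhibition far more strongly than that first step revealed, and among these three compounds the weakest inhibition belongs to the shortest chain, the only one with a double bond outside the hydroxamic acid's carbonyl. No measurement available here accounts for the size of this loss.

The change alters chain length and introduces the carbon-carbon double bond at the same time, so the compounds shown cannot divide the loss between the two, and the saturated 2-(hydroxycarbamoyl)ethyl group would be the direct test of that question. On these data alone, whether the numbers keep falling beyond compound 2 also remains open, and a longer chain such as 5-(hydroxycarbamoyl)pentyl on the same sulfur would address it.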